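This account rests on a few compounds, and the source may have more. Where it says the series, first, only, none or still open, it means among the compounds named here.

In an assay on HEK293 cells for displacement of a labelled ligand from C-C chemokine receptor type 4 (Homo sapiens) (on this read-out higher numbers stand for weaker inhibition and lower numbers for stronger inhibition), the measured compounds are:

compound 1 `CN1CCCC(C(=O)N2CCN(c3nccc(NCc4ccc(Cl)cc4Cl)n3)CC2)C1`, giving 700 nM.
compound 2 `O=C(C1CCNCC1)N1CCN(c2nccc(NCc3ccc(Cl)cc3Cl)n2)CC1`, for which only a limit is reported, > 10000 nM.
compound 3 `O=C([C@H]1CCCN1)N1CCN(c2nccc(NCc3ccc(Cl)cc3Cl)n2)CC1`, giving 60 nM.

Compound 3 has the lowest of the two numbers in this assay; the nearest is compound 1, and the step of a 12-fold lower number from compound 1 to compound 3 (1.07 log units; beyond the scatter) is well beyond the scatter. Compound 2 sits at the limit of > 10000 nM in this assay, at which 1 of the 3 values shown sits.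

Compound 4 `O=C(C1CCCNC1)N1CCN(c2nccc(NCc3ccc(Cl)cc3Cl)n2)CC1` differs from compound 3 in one place: piperidin-3-yl in place of pyrrolidin-2-yl on a carbonyl carbon. Among the compounds with values here, two measured steps bear on this change, and both lead from a six-membered ring on the carbonyl carbon to pyrrolidin-2-yl: a 12-fold lower number from compound 1 to compound 3 (1.07 log units; beyond the scatter) and an at least 160-fold lower number from compound 2 to compound 3 (2.22 log units; beyond the scatter). Each was large and in the same direction, so the reverse move, from pyrrolidin-2-yl to a six-membered ring, is expected to give a higher number in this assay. Within the data shown here, compound 1 carries 1-methylpiperidin-3-yl and compound 4 piperidin-3-yl; no measured pair separates the methyl from the ring change, so compound 1 is taken as the closest guide, with the piperidin-4-yl result of compound 2 marking the weaker end.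

The step from compound 3 to compound 4 is therefore expected to read a 17-fold higher number from compound 3 to compound 4 (1.22 log units; beyond the scatter). Compound 4 is estimated at 1000 nM in this assay, within 250 nM to 5000 nM.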

Compound 4, half-maximal inhibitory concentration: 800 nM
Compound 4: the middle estimate sits 1.3-fold (0.10 log units) above what was measured, and the stated range covers the measured number.
By their numbers in this assay, from the lowest: compound 3; then compounds 1 and 4 (each within the scatter of the next). At a limit, above all of these: compound 2.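

In this assay the methyl on the ring amine nitrogen now separates from the ring change, and removing it leaves the number within the scatter (a 1.1-fold higher number from compound 1 to compound 4 (0.06 log units; within the scatter)). The large loss against the pyrrolidin-2-yl amide therefore persists with no methyl present (a 13-fold higher number from compound 3 to compound 4 (1.12 log units; beyond the scatter)), while piperidin-3-yl still reads clearly better than piperidin-4-yl on the same carbonyl carbon (an at least 12-fold lower number from compound 2 to compound 4 (1.09 log units; beyond the scatter)). Compound 2 remains a limit and not a number: the limit of > 10000 nM in this assay, at which 1 of the 4 values shown sits.

Compound 3 carries a defined stereocentre and the piperidin-3-yl group of compound 4 carries none, so the compounds shown do not divide the step between ring size, the place of the ring nitrogen and stereochemistry; the opposite enantiomer of pyrrolidin-2-yl or a pyrrolidin-3-yl group would address that. As far as these compounds go, it also stays open whether the ring amine is needed at all, which a cyclopentyl group or an open-chain aminomethyl group on the carbonyl carbon would test, and whether a methyl on the pyrrolidine nitrogen is as silent as it is on the piperidin-3-yl ring.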